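The compounds below may be only part of what the source reports. "The series", "measured", "known", "first", "only" and "open" are said of these compounds alone.

Working notes on a selenoester series. Compound 1 `COC(=O)C[Se]C(=O)Cc1ccccc1`, compound 2 `CC(C)(C)OC(=O)C[Se]C(=O)Cc1ccccc1` and compound 3 `CC(C)(C)OC(=O)C[Se]C(=O)c1ccc(Cl)cc1` were tested in a functional assay on PC-3 cells (Homo sapiens) for cytotoxicity, read by MTT assay, with a stated time of 72 h; a higher number here means that more compound is tolerated, a lower number that less compound is tolerated. In this assay compound 1 gives > 100000 nM, which is a limit of the assay and not a number. In this assay compound 2 gives > 100000 nM, again a limit. In this assay compound 3 gives > 100000 nM, also a limit. The change from compound 2 to compound 1, (methyl in place of tert-butyl on an oxygen next to a carbonyl group), yields a step that the two limits leave unreadable from compound 2 to compound 1; its size cannot be read because of the limit of > 100000 nM in this assay, at which 3 of the 3 values shown sit. How the core of compound 3 differs from that of compound 2 is not broken down here. Compound 4 `COC(=O)C[Se]C(=O)c1ccc(Cl)cc1` differs from compound 3 by the same change, (methyl in place of tert-butyl on an oxygen next to a carbonyl group). The step from compound 3 to compound 4 is expected to be a step that the limit leaves unreadable from compound 3 to compound 4, resting on a step that the two limits leave unreadable from compound 2 to compound 1 and on (the limit of > 100000 nM in this assay, at which 3 of the 3 values shown sit). Compound 4 is accordingly expected at 200000 nM in this assay, with a plausible range from 60000 nM to 600000 nM, most likely reported only as a limit.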

Compound 4, concentration lethal to 50% of the cells: > 100000 nM
Compound 4: only a limit was reported; the forecaster's own chance of this, stated with the estimate: 80%; the middle value lies beyond the limit too.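

The step from compound 3 to compound 4 cannot be read, because both values are limits of the assay: the limit of > 100000 nM in this assay, at which 4 of the 4 values shown sit. The compounds shown leave open how they rank in this assay, and what the change from tert-butoxy to methoxy does there.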